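A few compounds are considered here, and "the series" means these few. Any claim that something is new, unique, unknown or untested is made for them only; others in the source may bear on it.

Compound 2 `Oc1ccc(-c2cc(-c3cccnc3)nc(-c3cccc(Cl)c3)c2)cc1` was examined in an ADME assay on HEK293 cells (Homo sapiens) for cytotoxicity, read by CCK-8 assay and cell counting, with a stated time of 2 days (a higher number here means a weaker inhibitor, a lower number a stronger inhibitor), where compound 2 gives 25700 nM. Its closest neighbour, compound 1 `Oc1ccc(-c2cc(-c3ccc(Cl)cc3)nc(-c3cccnc3)c2)cc1`, gives 27500 nM in this assay, and the step of a 1.1-fold lower number from compound 1 to compound 2 (0.03 log units; within the scatter) places the two within the scatter of each other. Compound 3 `Oc1ccc(-c2cc(-c3cccnc3)nc(-c3ccccc3Cl)c2)cc1` has "not determined" (no result reported) in this assay. Compound 4 `Oc1ccc(-c2cc(-c3ccccc3)nc(-c3cccc(Cl)c3)c2)cc1` differs from compound 2 by phenyl in place of pyridin-3-yl on an aromatic carbon. For the measured compounds named here, none of the measured steps concerns this kind of exchange; the single measured step, between the two chlorophenyl variants, stayed within the scatter. The numbers therefore give no ground to expect a step beyond the scatter, and the expected step is a 1.0-fold lower number from compound 2 to compound 4 (0.01 log units; within the scatter). Compound 4 is estimated at 25000 nM in this assay, with a range from 9000 nM to 70000 nM.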

Compound 4, half-maximal inhibitory concentration: 2820 nM
For compound 4 the middle estimate is 8.9-fold (0.95 log units) above the measured one; measured number below the stated range.
By their numbers in this assay, from the lowest: compound 4; then compounds 2 and 1 (each within the scatter of the next).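

In this assay, for the compounds shown here, phenyl in place of pyridin-3-yl on the aromatic carbon next to the ring nitrogen gives a 9.1-fold lower number from compound 2 to compound 4 (0.96 log units; beyond the scatter) and so lies beyond the scatter, unlike the only earlier measured step. The exchange keeps the heavy-atom count of the group and replaces its ring nitrogen with carbon, so this position is sensitive to a change of a single ring atom.

On these data alone, whether the step recurs alongside 4-chlorophenyl, and how an amine or a carboxylic acid on the phenyl would read, stays open. Nothing shown accounts for the step.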